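A Second Chloro Group on the Shared Core

The source may hold more compounds than are shown below. What is called first, only, known or untested is meant among the compounds shown, and "the series" means these compounds.

Four compounds built on one shared core belong to this set. Compound 1 `ClCc1ccccc1Cn1cnc2c(Cl)nc(Cl)nc21` and compound 2 `ClCc1cccc(Cn2cnc3ncnc(Cl)c32)c1` were included in a functional assay on SNB-19 cells (Homo sapiens) for cytotoxicity, read by sulforhodamine B assay, with a stated time of 48 h (a lower number here means a stronger inhibitor of growth, a higher number a weaker inhibitor of growth), yet compound 1 gave "not determined" (no result reported) and compound 2 gave "not determined" (no result reported), leaving no number for either. Within the data shown here, compound 3 `ClCc1cccc(Cn2cnc3c(Cl)ncnc32)c1` is the only compound with a result: in this assay compound 3 gives 12600 nM, which places it as the single point of reference here, with nothing measured to rank it against.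

Compound 4 `ClCc1cccc(Cn2cnc3c(Cl)nc(Cl)nc32)c1` differs from compound 3 in one place: chloro in place of hydrogen on an aromatic carbon, on an aromatic carbon of a six-membered aromatic ring with two nitrogens, between two ring nitrogen atoms, meta to a chloro group, meta to a fused ring, and para to a fused ring. Among the measured compounds shown here, no pair of measured compounds shows what this change does within the set, and no measured step exists to lean on. With only the value of compound 3 available, the expected step from compound 3 to compound 4 is a 1.6-fold lower number from compound 3 to compound 4 (0.20 log units; within the scatter), a modest move toward stronger growth inhibition that may well remain within the scatter. On that basis compound 4 is expected to give 8000 nM in this assay, with a range from 2500 nM to 25000 nM.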

Compound 4, concentration for total growth inhibition: 4160 nM
For compound 4 the middle estimate is 1.9-fold (0.28 log units) above the measured one; the range from low to high includes it.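

Placing chloro in place of hydrogen on the aromatic carbon between two ring nitrogen atoms gives a 3.0-fold lower number from compound 3 to compound 4 (0.48 log units; beyond the scatter) in this assay. Among these compounds, this is the first measured step in the set, and it shows that this position is not silent: a single added chlorine atom moves the number by more than the usual scatter of repeated measurements, though only modestly, and toward stronger inhibition of growth. The data shown include no independent measurement that could explain the size or direction of this step.

Among the compounds shown here, compound 1 and compound 2 carry no number, so no step involving either of them can be read, and the whole account of this position rests on a single pair. Going by these compounds, it remains open whether a different group on this same aromatic carbon, such as an amine or a methoxy group, would shift the number in the same direction or by a similar amount, and whether chloro here would have the same effect with the rest of the molecule changed.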